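The compounds below may be only part of what the source reports. "The series", "measured", "known", "first", "only" and "open" are said of these compounds alone.

Measured in a functional assay on cells (Melanoma cell, Homo sapiens) for inhibition; a higher number here means a weaker inhibitor of growth, a lower number a stronger inhibitor of growth:
- compound 1 `Cc1cc(-c2nc3sc(C)cn3c2/C=N/NC(=N)N)c(C)s1`: 7410 nM
- compound 2 `N=C(N)N/N=C/c1c(-c2ccsc2)nc2sccn12`: 17000 nM
- compound 3 `N=C(N)N/N=C/c1c(-c2cccs2)nc2sccn12`: 15100 nM

Compound 3 lies within the scatter of compound 2, and its number is higher than that of compound 1. The next compound, compound 4 `Cc1cc(-c2nc3sccn3c2/C=N/NC(=N)N)c(C)s1`, has 2,5-dimethylthiophen-3-yl in place of thiophen-2-yl on an aromatic carbon.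

Within the data shown here, the only measured step, a 1.1-fold lower number from compound 2 to compound 3 (0.05 log units; within the scatter), shows that swapping thiophen-3-yl for thiophen-2-yl changes little. The closest guide is compound 1, which carries the same 2,5-dimethylthiophen-3-yl group plus a methyl on the shared core and gives 7410 nM. A modest drop is therefore expected, a 1.6-fold lower number from compound 3 to compound 4 (0.20 log units; within the scatter). The estimate for compound 4 is 9500 nM, with an expected range of 5000 nM to 17000 nM.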

Compound 4, concentration for 50% growth inhibition: 16200 nM
Compound 4: the middle estimate sits 1.7-fold (0.23 log units) below what was measured, within the range that was stated.
By their numbers in this assay, from the lowest: compound 1; then compounds 3, 4 and 2 (each within the scatter of the next).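

In this assay the 2,5-dimethylthiophen-3-yl group on this aromatic carbon stays within the scatter of both plain thiophenes (a 1.1-fold higher number from compound 3 to compound 4 (0.03 log units; within the scatter)) and (a 1.0-fold lower number from compound 2 to compound 4 (0.02 log units; within the scatter)). The gap beyond the scatter appears only against compound 1, which differs from compound 4 by a methyl on the shared core (a 2.2-fold higher number from compound 1 to compound 4 (0.34 log units; beyond the scatter)), so here the lower number goes with that core methyl and not with the thiophene methyls alone. No measurement offered here explains this. Still open, from the compounds shown here alone, is whether the core methyl would act the same way on compound 2 or compound 3, and whether an amine or a carboxylic acid on the thiophene would move the number.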